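Varying the group on the ring nitrogen: compound 4

This account rests on a few compounds, and the source may have more. Where it says the series, first, only, none or still open, it means among the compounds named here.

Compound 3 `CC(C)c1onc(-c2c(Cl)cccc2Cl)c1COc1ccc(-c2nc3ccc(C(=O)O)cc3n2Cc2ccc(F)cc2)cc1` carries a 4-fluorobenzyl group on the ring nitrogen of the shared core; in an assay on isolated protein for agonist activity at Bile acid receptor (Homo sapiens), read by TR-FRET (on this read-out higher numbers stand for an effect only at larger amounts of compound and lower numbers for an effect already at smaller amounts), compound 3 gives 105 nM. This is the higher of the two numbers recorded. Compound 1 `CCn1c(-c2ccc(OCc3c(-c4c(Cl)cccc4Cl)noc3C(C)C)cc2)nc2ccc(C(=O)O)cc21`, with an ethyl group in the same place, gives 19.3 nM in this assay, and the step of a 5.4-fold higher number from compound 1 to compound 3 (0.74 log units; beyond the scatter) lies beyond the scatter. Compound 2 `CC(=O)N1CCC(n2c(-c3ccc(OCc4c(-c5c(Cl)cccc5Cl)noc4C(C)C)cc3)nc3ccc(C(=O)O)cc32)CC1` carries an acetylated saturated ring there and gives "not determined" (no result reported) in this assay, so it contributes no number.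

Compound 4 `CCCC(CCC)n1c(-c2ccc(OCc3c(-c4c(Cl)cccc4Cl)noc3C(C)C)cc2)nc2ccc(C(=O)O)cc21` changes the same position once more: 1-propylbutyl in place of 4-fluorobenzyl on an aromatic nitrogen. Going by the values given here, only the single step from compound 1 to compound 3 bears on this change, and it concerned a different exchange at the same nitrogen, so the direction for a branched chain cannot be fixed from it. Given that a small chain in compound 1 gave 19.3 nM and the 4-fluorobenzyl in compound 3 gave 105 nM, compound 4 is expected to fall between them, a step of a 2.1-fold lower number from compound 3 to compound 4 (0.32 log units; beyond the scatter) toward a lower number. For compound 4 in this assay the estimate is 50 nM, with a range from 15 nM to 200 nM.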

Compound 4, half-maximal effective concentration: 30.3 nM
For compound 4 the middle estimate is 1.7-fold (0.22 log units) above the measured one; measured number inside the range.
By their numbers in this assay, from the lowest: compounds 1 and 4 (each within the scatter of the next); then compound 3.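

In this assay, the change to a chain without a ring gives a 3.5-fold lower number from compound 3 to compound 4 (0.54 log units; beyond the scatter), so the higher number of compound 3 does not follow from every group bigger than ethyl on this aromatic nitrogen. The step of a 1.6-fold higher number from compound 1 to compound 4 (0.20 log units; within the scatter) stays within the scatter, so ethyl and 1-propylbutyl are not told apart at this position, and for these two compounds the readings show no dependence on chain size or branching. No measurement at hand accounts for either step.

On these data alone, whether the higher number of compound 3 goes with the aromatic ring or with its fluorine stays open, and a plain benzyl group would separate the two. As far as these compounds go, how an unbranched heptyl chain, or a chain ending in an amine or a carboxylic acid, would read at this nitrogen also remains open.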